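Trisubstituted-phenyl pyrazole enones: cytotoxicity at one concentration

The compounds below may be only part of what the source reports. "The series", "measured", "known", "first", "only" and "open" are said of these compounds alone.

Measured compounds and values:
compound 1 `COc1cc(-c2cc(/C=C/C(=O)c3ccc(N)cc3)[nH]n2)cc(OC)c1OC` gives 94%
compound 2 `COc1cc(-c2cc(/C=C/C(=O)c3ccc(Cl)c(Cl)c3)[nH]n2)cc(OC)c1OC` gives 94%
compound 3 `COc1ccc(C(=O)/C=C/c2cc(-c3cc(OC)c(OC)c(OC)c3)n[nH]2)cc1OC` gives 98%

All three values come from a functional assay on HCT-15 cells (Homo sapiens) for cytotoxicity, read by sulforhodamine B assay, with a stated time of 48 h, tested at 0.1 uM; on this read-out lower numbers stand for a stronger effect and higher numbers for a weaker effect at the one concentration tested. The three compounds share a core and differ only in the aryl group on the carbonyl carbon. Compound 3 has the highest of the three numbers, but its gap to compound 1 and to compound 2 is within the scatter, so no order among the three can be read from this assay.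

Compound 4 `COc1ccc(C(=O)/C=C/c2cc(-c3cc(OC)c(OC)c(OC)c3)n[nH]2)cc1` is not yet measured. It differs from compound 3 in one place: hydrogen in place of methoxy on an aromatic carbon.

The steps bearing on this change are those that alter the same aryl group on the carbonyl carbon: no change at the digits printed from compound 1 to compound 2 (within the scatter), a number 4 percentage points higher from compound 1 to compound 3 (within the scatter) and a number 4 percentage points higher from compound 2 to compound 3 (within the scatter). None of them moves the number beyond the scatter, even where an amino, a dichloro and a dimethoxy pattern are exchanged. Removing one methoxy group is a smaller change than any of these, so no step beyond the scatter is expected in this assay; the expected step is a number 2 percentage points lower from compound 3 to compound 4 (within the scatter). Compound 4 is therefore estimated at 96%, with a range from 86% to 104%.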

Compound 4, a percentage reported as activity, at one concentration (the size of the read-out at that concentration, not a potency): 100%
Beside the measured number, compound 4's estimate is 4 percentage points below it; measured number inside the range.
By their numbers in this assay, from the lowest: compounds 1, 2, 3 and 4 (each within the scatter of the next).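

In this assay, the change from 3,4-dimethoxyphenyl to 4-methoxyphenyl gives a number 2 percentage points higher from compound 3 to compound 4 (within the scatter) and so shows that this aromatic carbon, ortho to a methoxy group, tolerates hydrogen in place of methoxy without a readable shift at the one concentration tested. The 4-methoxyphenyl group also stays level with the two other aryl groups, with a number 6 percentage points higher from compound 2 to compound 4 (within the scatter) and a number 6 percentage points higher from compound 1 to compound 4 (within the scatter) as the steps, so compound 4 adds a further aryl pattern without any step beyond the scatter. Nothing available bears on why these values sit where they do.

As far as these compounds go, whether this position has any influence on cytotoxicity remains open, since all four compounds give similar numbers at this one concentration. Also open, from the compounds shown here alone, is how an aryl group carrying a carboxylic acid or a longer chain such as butoxy would behave here.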